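A few compounds are considered here, and "the series" means these few. Any claim that something is new, unique, unknown or untested is made for them only; others in the source may bear on it.

Compound 1 `Cc1ccc(S(=O)(=O)Oc2ccccc2/C=C(\C#N)C(=O)Nc2nnc(C)s2)cc1`: in a functional assay on RS4-11 cells (Homo sapiens) for inhibition, read by CCK-8 assay, with a stated time of 48 h (a higher number here means a weaker inhibitor, a lower number a stronger inhibitor), compound 1 gives > 20000 nM, which is a limit of the assay rather than a number.
Compound 2 `COc1ccc(S(=O)(=O)Oc2ccccc2/C=C(\C#N)C(=O)Nc2nnc(-c3cccs3)s2)cc1`: in this assay compound 2 gives 4750 nM.
Compound 3 `Cc1ccc(S(=O)(=O)Oc2cccc(/C=C(\C#N)C(=O)Nc3nnc(C)s3)c2)cc1`: in this assay compound 3 gives > 20000 nM, again a limit of the assay rather than a number.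

Compound 3 therefore stands at the weak end of what has been measured, sitting at the limit of > 20000 nM in this assay, at which 2 of the 3 values shown sit. Within the data shown here, compound 4 `Cc1ccc(S(=O)(=O)Oc2cccc(/C=C(\C#N)C(=O)Nc3nnc(-c4cccs4)s3)c2)cc1` keeps everything else of compound 3 and changes only one group: thiophen-2-yl in place of methyl on an aromatic carbon. No measured pair among these three compounds differs in this one place alone, so the size of such a step is not known directly. Compound 2, which also carries thiophen-2-yl on the same ring, does give a number, whereas compound 1, which carries methyl there, sits at the limit; these two compounds differ in more than one place, so their two values show only that a thiophen-2-yl bearer has reached a measurable value. For compound 4 a step from compound 3 toward stronger inhibition is expected, an at least 2.2-fold lower number from compound 3 to compound 4 (0.34 log units; beyond the scatter), though it may still end at the limit. Compound 4 is estimated at 9000 nM, between 3000 nM and 25000 nM.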

Compound 4, half-maximal inhibitory concentration: > 20000 nM
Compound 4 was reported as a limit (the forecaster's own chance of this, stated with the estimate: 40%); middle value at least 2.2-fold (0.34 log units) from the limit.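

Compound 3 and compound 4 both end at a limit of this assay rather than at a number, so the step between them cannot be read: the limit of > 20000 nM in this assay, at which 3 of the 4 values shown sit. The compounds shown leave open whether thiophen-2-yl in place of methyl changes inhibition at all on this core.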